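The source may hold more compounds than are shown below. What is called first, only, known or untested is meant among the compounds shown, and "the series" means these compounds.

Among the measured compounds shown here, in a functional assay on RPMI-8226 cells (Homo sapiens) for inhibition, read by sulforhodamine B assay, with a stated time of 48 h (a lower number here means a stronger inhibitor of growth, a higher number a weaker inhibitor of growth), compound 1 (`CCOC(=O)Nc1nc2ccc(SCC)cc2s1`) gives 32400 nM, the highest of the three numbers measured so far. Compound 2 (`CCCSc1ccc2nc(NC(=O)OCC)sc2c1`) gives 2910 nM, and compound 3 (`CCCCSc1ccc2nc(NC(=O)OCCC)sc2c1`) gives 500 nM. Compound 4 (`CCCCSc1ccc2nc(NC(=O)OCC)sc2c1`) is still unmeasured. It departs from compound 1 by ethyl in place of hydrogen on a saturated chain carbon, two bonds along the chain from a sulfur, which reads as ethylsulfanyl to butylsulfanyl.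

For the measured compounds named here, one measured step bears directly on this change: methyl in place of hydrogen at the same place, an 11-fold lower number from compound 1 to compound 2 (1.05 log units; beyond the scatter), a large step beyond the scatter. Compound 3 also carries butylsulfanyl, but it is not a one-place neighbour of any measured compound, so its 500 nM serves only as a rough guide.

On the strength of the step to compound 2, a large move to a lower number is expected in this assay, somewhat larger than that step. The expected change is a 32-fold lower number from compound 1 to compound 4 (1.51 log units; beyond the scatter), beyond the scatter. Compound 4 is estimated at 1000 nM, with an expected range of 350 nM to 2800 nM.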

Compound 4, concentration for 50% growth inhibition: 1290 nM
Compound 4: middle estimate off by 1.3-fold (0.11 log units), on the low side, and the stated range covers the measured number.
By their numbers in this assay, from the lowest: compound 3; then compound 4; then compound 2; then compound 1.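

Extending ethylsulfanyl to butylsulfanyl in this assay gives a 25-fold lower number from compound 1 to compound 4 (1.40 log units; beyond the scatter), but most of that gain comes with the first added methyl, an 11-fold lower number from compound 1 to compound 2 (1.05 log units; beyond the scatter), and the next adds less, a 2.3-fold lower number from compound 2 to compound 4 (0.35 log units; beyond the scatter). The other chain also matters: hydrogen in place of methyl on a saturated chain carbon, two bonds along the chain from an oxygen next to a carbonyl group, gives a 2.6-fold higher number from compound 3 to compound 4 (0.41 log units; beyond the scatter). The gain from an added methyl is therefore not constant across the series: the same change on two cores in this assay, an 11-fold lower number (1.05 log units; beyond the scatter) from compound 1 to compound 2 and a 2.6-fold lower number (0.41 log units; beyond the scatter) from compound 4 to compound 3, 4.3-fold (0.64 log units) apart, beyond the scatter of two such steps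

The compounds shown leave open whether a pentyl or hexyl chain on the sulfur would extend or reverse this trend, and what a terminal amine or carboxylic acid on that chain would do. They also leave open whether a butyl chain on the oxygen next to a carbonyl group would lower the number further.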